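The source may hold more compounds than are shown below. What is called first, only, known or untested is meant among the compounds shown, and "the series" means these compounds.

In an ADME assay on liver (Mus musculus) for metabolic stability, read by LC-MS, using microsomes and NADPH (on this read-out higher numbers stand for a more stable compound and lower numbers for a less stable compound), compound 1 (`CCCN(Cc1ccc(OCCN2C(=O)CCC2=O)c(C)c1)C(CC(=O)O)c1ccc(Cl)cc1`) gives 75% and compound 2 (`CCCCN(Cc1ccc(OCCN2C(=O)CCC2=O)c(C)c1)C(CC(=O)O)c1ccc(Cl)cc1`) gives 88% while compound 3 (`Cc1cc(CN(CC2CCCC2)C(CC(=O)O)c2ccc(Cl)cc2)ccc1OCCN1C(=O)CCC1=O`) gives 52% as the lowest of the three numbers. Compound 4 (`Cc1cc(CN(CC2CCCCC2)C(CC(=O)O)c2ccc(Cl)cc2)ccc1OCCN1C(=O)CCC1=O`) differs from compound 3 by one change (cyclohexyl in place of cyclopentyl on a saturated chain carbon bound to an amine nitrogen) with cyclohexyl in place of cyclopentyl on a saturated chain carbon bound to an amine nitrogen. For the measured compounds named here, no measured step exchanges one ring for another. The nearest steps, which bring in cyclopentyl, gave a number 23 percentage points lower from compound 1 to compound 3 (beyond the scatter) and a number 36 percentage points lower from compound 2 to compound 3 (beyond the scatter) while methyl in place of hydrogen on the chain gave a number 13 percentage points higher from compound 1 to compound 2 (beyond the scatter) in the opposite direction. With this mixed evidence, the expected result in this assay is a number 4 percentage points lower from compound 3 to compound 4 (within the scatter) and no shift beyond the scatter. For compound 4 the estimated value is 48% (expected range 28% to 68%).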

Compound 4, percent of the compound remaining: 57%
For compound 4 the middle estimate is 9 percentage points below the measured one, and the stated range covers the measured number.
By their numbers in this assay, from the lowest: compounds 3 and 4 (each within the scatter of the next); then compound 1; then compound 2.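

Cyclohexyl in place of cyclopentyl, on a saturated chain carbon bound to an amine nitrogen, is the first exchange of one ring for another at this position in this assay, and it stays within the scatter (a number 5 percentage points higher from compound 3 to compound 4 (within the scatter)). Compound 4 also lies beyond the scatter below both open-chain compounds (a number 31 percentage points lower from compound 2 to compound 4 (beyond the scatter); a number 18 percentage points lower from compound 1 to compound 4 (beyond the scatter)), as compound 3 does, so the gap to these chains holds for both rings. Nothing available here accounts for these numbers.

On these data alone, whether a smaller ring such as cyclopropyl, a ring holding an oxygen atom such as tetrahydropyranyl, or a longer chain such as pentyl would follow the rings or the chains remains open.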